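This account rests on a few compounds, and the source may have more. Where it says the series, first, only, none or still open, it means among the compounds named here.

Compound 1, `CCCNc1ccc(NC(=O)c2cc(Cl)ccc2O)c(Cl)c1`, is measured in an ADME assay on A549 cells (Homo sapiens) for cytotoxicity, read by resazurin assay, with a stated time of 48 h (a higher number here means that more compound is tolerated, a lower number that less compound is tolerated), and gives 22500 nM. Two further compounds share its core. Compound 2, `CCCCCCC(C)Nc1ccc(NC(=O)c2cc(Cl)ccc2O)c(Cl)c1`, gives 23500 nM, and compound 3, `O=C(Nc1ccc(NCc2ccc(Br)cc2)cc1Cl)c1cc(Cl)ccc1O`, gives 40900 nM. Among these three numbers compound 1 stands at the low end, yet the step of a 1.0-fold higher number from compound 1 to compound 2 (0.02 log units; within the scatter) and the step of a 1.8-fold higher number from compound 1 to compound 3 (0.26 log units; within the scatter) both lie within the scatter, so the three compounds are not separated in this assay.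

Compound 4, `O=C(Nc1ccc(NCc2cc(Cl)cc(Cl)c2)cc1Cl)c1cc(Cl)ccc1O`, has not yet been measured. It differs from compound 1 by 3,5-dichlorophenyl in place of ethyl on a saturated chain carbon bound to a nitrogen on an aromatic ring. The closest guide is the step from compound 1 to compound 3, where a 4-bromophenyl entered at the same place as the 3,5-dichlorophenyl does here, and that step, a 1.8-fold higher number from compound 1 to compound 3 (0.26 log units; within the scatter), stayed within the scatter. The step of a 1.7-fold higher number from compound 2 to compound 3 (0.24 log units; within the scatter) likewise stayed within the scatter when a substituted benzyl replaced an alkyl chain on the same nitrogen. On this basis compound 4 is expected to sit near compound 1 and compound 3, with a step of about a 1.6-fold higher number from compound 1 to compound 4 (0.19 log units; within the scatter), not clearly beyond the scatter. The estimated value for compound 4 in this assay is 35000 nM, within a range from 17000 nM to 72000 nM.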

Compound 4, half-maximal cytotoxic concentration: 13300 nM
Compound 4: the middle estimate sits 2.6-fold (0.42 log units) above what was measured; the whole stated range lies above it.
By their numbers in this assay, from the lowest: compounds 4, 1, 2 and 3 (each within the scatter of the next, the first and the last beyond it).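

Within the data shown here, at the saturated chain carbon bound to a nitrogen on an aromatic ring, the choice of aryl group now separates two compounds in this assay: putting 3,5-dichlorophenyl in place of 4-bromophenyl gives a 3.1-fold lower number from compound 3 to compound 4 (0.49 log units; beyond the scatter), the only single-place step in this set that lies beyond the scatter. Set against the alkyl groups on the same nitrogen, the 3,5-dichlorobenzyl group is not separated, with a 1.7-fold lower number from compound 1 to compound 4 (0.23 log units; within the scatter) and a 1.8-fold lower number from compound 2 to compound 4 (0.25 log units; within the scatter), so the separation rests on this one pair of aryl groups and not on any general contrast between benzyl and alkyl. Nothing available accounts for the difference between the two aryl groups.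

The two aryl groups differ both in their halogen and in the ring places it occupies, so the compounds shown cannot tell which of the two goes with the step from compound 3 to compound 4. On these data alone, it also remains open where an unsubstituted phenyl, a 4-chlorophenyl or a 3,5-dibromophenyl would fall at this carbon, and these would pull the two differences apart.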